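The source may report more compounds than this note shows. Statements on the series, on what has been measured and on what is new or still open speak of the compounds shown alone.

Measured so far, with the half-maximal inhibitory concentration in a functional assay on B16-F10 cells (Mus musculus) for inhibition, read by colorimetric assay and MTT assay, with a stated time of 72 h; a higher number here means a weaker inhibitor, a lower number a stronger inhibitor:
compound 1, `COc1cc(C(=O)NNC(=S)Nc2csc(-c3ccc(C)cc3)c2)cc(OC)c1OC`: 13000 nM
compound 2, `COc1ccc(C(=O)NNC(=S)Nc2csc(-c3ccc(C)cc3)c2)cc1`: 9000 nM
compound 3, `COc1ccc(C(=O)NNC(=S)Nc2csc(-c3ccccc3)c2)cc1OC`: 9000 nM

Compound 3 sits level with compound 2 at the digits shown, the two together the lowest of the three numbers, and its gap to compound 1 also stays within the scatter of this assay. All three therefore read as one cluster, with no ordering that can be trusted.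

Compound 4, `COc1ccc(C(=O)NNC(=S)Nc2csc(-c3ccc(C)cc3)c2)cc1OC`, is not yet measured. It differs from compound 3 in one place: methyl in place of hydrogen on an aromatic carbon, the change reading as phenyl to 4-methylphenyl when cut one bond further out. Going by the values given here, no step between measured compounds isolates this change. Compounds 1 and 2 both carry the 4-methylphenyl and fall inside the same cluster as compound 3, which gives no sign that the methyl moves the number far in either direction.

The expectation for compound 4 is therefore a step from compound 3 of no change at the digits printed from compound 3 to compound 4 (within the scatter), none beyond the scatter. Compound 4 is estimated at 9000 nM, within 4000 nM to 20000 nM.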

Compound 4, half-maximal inhibitory concentration: 7000 nM
The estimate for compound 4 lay 1.3-fold (0.11 log units) above the measured number; measured number inside the range.
By their numbers in this assay, from the lowest: compounds 4, 2, 3 and 1 (each within the scatter of the next).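

In this assay the change of methyl in place of hydrogen on an aromatic carbon, para to a large group, now stands alone as a single step: phenyl to 4-methylphenyl gives a 1.3-fold lower number from compound 3 to compound 4 (0.11 log units; within the scatter), so this position tolerates the methyl without a readable shift in the number. With the 4-methylphenyl held fixed, the two single changes of methoxy and hydrogen on an aromatic carbon read the same way, with methoxy in place of hydrogen giving a 1.3-fold lower number from compound 2 to compound 4 (0.11 log units; within the scatter) and hydrogen in place of methoxy giving a 1.9-fold lower number from compound 1 to compound 4 (0.27 log units; within the scatter), so none of the three changes separates from the scatter. Nothing measured here speaks to a cause for the size of these steps.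

The compounds shown cover only hydrogen, methyl and methoxy at these places, so they give no sign of what a chlorine, a trifluoromethyl, an amine, a carboxylic acid or a longer chain such as butyl would do to the number. Going by these compounds, whether any change on this scaffold can move the number beyond the scatter remains open.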